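A few compounds are considered here, and "the series" means these few. Any claim that something is new, unique, unknown or untested is made for them only; others in the source may bear on it.

Measured in an ADME assay on microsomes from liver (Mus musculus) for metabolic stability, read by HPLC, using NADPH, with a stated time of 60 min, tested at 1 uM, in the presence of a further agent that is not named here; on this read-out lower numbers stand for a shorter-lived compound and higher numbers for a longer-lived compound:
- compound 1 `Cc1cc(-c2ncccn2)cc(C(=O)NNS(=O)(=O)c2ccccc2)c1F`: 0.1 h
- compound 2 `Cc1cc(-n2cccn2)cc(C(=O)NNS(=O)(=O)c2ccccc2)c1F`: 0.05 h
- compound 3 `Cc1cc(-n2nccn2)cc(C(=O)NNS(=O)(=O)c2ccccc2)c1F`: 0.0333 h

Compound 3 stands clearly apart from only one of the other two. The data show a 3.0-fold lower number from compound 1 to compound 3 (0.48 log units; beyond the scatter), and also a 1.5-fold lower number from compound 2 to compound 3 (0.18 log units; within the scatter).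

The next compound to read is compound 4 `C=CCOc1cc(C)c(F)c(C(=O)NNS(=O)(=O)c2ccccc2)c1`, with allyloxy in place of 2H-1,2,3-triazol-2-yl on an aromatic carbon.

The three measured steps all exchange one group for another at this same place. Alongside the two above, there is a 2.0-fold lower number from compound 1 to compound 2 (0.30 log units; within the scatter). Within the data shown here, only the step to compound 3 from compound 1 exceeds the scatter, and it is modest. Among the measured compounds shown here, none of the measured steps brings in a group without a ring, so they offer only weak guidance for this change and give no firm direction.

No step beyond the scatter is therefore expected in this assay. The middle of the expectation is set level with compound 2 at 0.05 h, inside the span of the measured numbers. The estimated change is a 1.5-fold higher number from compound 3 to compound 4 (0.18 log units; within the scatter). For compound 4 the estimated half-life is 0.05 h, with an expected range of 0.02 h to 0.12 h.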

Compound 4, half-life: < 0.0334 h
Compound 4: only a limit was reported; the forecaster's own chance of this, stated with the estimate: 10%; at least 1.4-fold (0.17 log units) between middle value and limit.
By their numbers in this assay, from the lowest: compounds 3, 2 and 1 (each within the scatter of the next, the first and the last beyond it).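

In this assay compound 4 gives < 0.0334 h, which is a limit of the assay and not a number. Among these compounds, it is the first group without a ring at this aromatic carbon, and allyloxy reads as an at least 2.9-fold lower number from compound 1 to compound 4 (0.47 log units; beyond the scatter), so leaving the ring out brings no gain in half-life over pyrimidin-2-yl, while the same change read against 1H-pyrazol-1-yl gives an at least 1.4-fold lower number from compound 2 to compound 4 (0.17 log units; that floor lies within the scatter), a floor that does not separate the two. The step between the 2H-1,2,3-triazol-2-yl and allyloxy compounds cannot be read, as the number for compound 4 is replaced by a limit: the limit of < 0.0334 h in this assay, at which 1 of the 4 values shown sits.

From the compounds shown here alone, whether the double bond of allyloxy matters stays open, as does the reading of a saturated propoxy chain, a shorter methoxy group, or an amine or carboxylic acid on this same aromatic carbon. All compounds shown keep the rest of the core unchanged, so how far the short half-lives depend on this place, rather than on the fluoro, methyl or phenylsulfonyl parts, also remains open.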